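Replacing the aminocyclohexyl group on compound 2

This account rests on a few compounds, and the source may have more. Where it says the series, first, only, none or still open, it means among the compounds named here.

In a functional assay on HCT-116 cells (Homo sapiens) for cytotoxicity, read by fluorescence, with a stated time of 72 h (on this read-out lower numbers stand for stronger inhibition and higher numbers for weaker inhibition), compound 1 `CSc1nc(NCc2ccc(-c3ccccn3)cc2)c2[nH]nc(C(C)C)c2n1` gives 2800 nM, and compound 2 `CC(C)c1n[nH]c2c(NCc3ccc(-c4ccccn4)cc3)nc(N[C@H]3CC[C@H](N)CC3)nc12` gives 720 nM, the lower of the two numbers. The next compound to be tested is compound 3 `COc1ccc(CNc2nc(NCc3ccc(-c4ccccn4)cc3)c3[nH]nc(C(C)C)c3n2)cc1`, which carries a new group on the same nitrogen as compound 2. The structural change is 4-methoxybenzyl in place of 4-aminocyclohexyl on a nitrogen on an aromatic ring.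

For the measured compounds named here, only one measured step bears on this change, and only indirectly. Putting (4-aminocyclohexyl)amino in place of methylsulfanyl on an aromatic carbon gave a 3.9-fold lower number from compound 1 to compound 2 (0.59 log units; beyond the scatter), a modest step beyond the scatter. Going by the values given here, no measured compound carries 4-methoxybenzyl, so the size of its contribution is unknown, and a single step cannot show which part of the 4-aminocyclohexyl group matters. Since compound 3 gives up that group, some of the gain seen in a 3.9-fold lower number from compound 1 to compound 2 (0.59 log units; beyond the scatter) is expected to be lost in this assay. The expected change, a modest move towards a higher number, is a 2.1-fold higher number from compound 2 to compound 3 (0.32 log units; beyond the scatter). For compound 3 the estimated value is 1500 nM, with an expected range of 450 nM to 5000 nM.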

Compound 3, half-maximal inhibitory concentration: 17400 nM
For compound 3 the middle estimate is 12-fold (1.06 log units) below the measured one; the whole stated range lies below it.
By their numbers in this assay, from the lowest: compound 2; then compound 1; then compound 3.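

In this assay, the group on this nitrogen has a larger effect than the earlier step showed: 4-methoxybenzyl in place of 4-aminocyclohexyl gives a 24-fold higher number from compound 2 to compound 3 (1.38 log units; beyond the scatter), a large step compared with the modest (a 3.9-fold lower number from compound 1 to compound 2 (0.59 log units; beyond the scatter)). The two amino replacements for methylsulfanyl also move in opposite directions, since (4-methoxybenzyl)amino gives a 6.2-fold higher number from compound 1 to compound 3 (0.79 log units; beyond the scatter), so the linking nitrogen alone does not bring the lower number seen with compound 2. No measurement here accounts for the gap between the two groups.

This single exchange changes the ring type, the amino group and the oxygen-bearing methoxy group together, so the part of 4-aminocyclohexyl that matters, and the part of 4-methoxybenzyl that costs, cannot be separated. A plain cyclohexyl group and a 4-aminobenzyl group on the same nitrogen would bear directly on that question, the first by removing the amino group from the non-aromatic ring and the second by placing an amino group on the aromatic ring.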